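Benzoyl to carbamoyl: compound 3 to compound 4

The compounds below may be only part of what the source reports. "The series", "measured", "known", "first", "only" and "open" are said of these compounds alone.

In a functional assay on V79-379A cells (Cricetulus griseus) for cytotoxicity, read by MTT assay, in the presence of a further agent that is not named here (a lower number here means a stronger inhibitor, a higher number a weaker inhibitor), compound 1 `COC1=CC(=O)c2c(c(CCl)cn2C)C1=O` gives 33000 nM. Compound 2 `COC1=CC(=O)c2c(c(COC(=O)c3ccc(F)cc3)cn2C)C1=O` gives 50 nM, and compound 3 `COC1=CC(=O)c2c(c(COC(=O)c3ccccc3)cn2C)C1=O` gives 40 nM. Compound 3 thus stands level with compound 2 within the scatter and far under compound 1.

Compound 4 `COC1=CC(=O)c2c(c(COC(N)=O)cn2C)C1=O` keeps the shared core and differs from compound 3 as follows: amino in place of phenyl on a carbonyl carbon. Cut one bond further out, this reads benzoyl to carbamoyl.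

Within the data shown here, only one measured step touches this part of the series: a 1.3-fold lower number from compound 2 to compound 3 (0.10 log units; within the scatter). Among the measured compounds shown here, that step swaps hydrogen for fluoro on an aromatic carbon and leaves the ring in place, so no measured step covers the loss of phenyl. Compound 1, which carries no benzoyl group, reads 33000 nM, against 40 nM for compound 3. The number can therefore move a long way when this part of the structure changes, yet compound 1 is too different to size the step directly.

A move to a higher number, meaning a weaker inhibitor, is expected, though the data fix its size only loosely. The expected step is a 5.0-fold higher number from compound 3 to compound 4 (0.70 log units; beyond the scatter). For compound 4 the estimated value is 200 nM, with an expected range of 30 nM to 2000 nM.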

Compound 4, half-maximal inhibitory concentration: 40 nM
The estimate for compound 4 lay 5.0-fold (0.70 log units) above the measured number; the range from low to high includes it.
By their numbers in this assay, from the lowest: compounds 3, 4 and 2 (each within the scatter of the next); then compound 1.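

In this assay, the aromatic ring on the carbonyl carbon proves dispensable in this series: amino replaces phenyl (no change at the digits printed from compound 3 to compound 4 (within the scatter)) and replaces 4-fluorophenyl (a 1.3-fold lower number from compound 2 to compound 4 (0.10 log units; within the scatter)) without a step beyond the scatter. The earlier pair changed only a substituent on that ring, whereas these steps remove the ring altogether, and the large gap to the chloro compound also holds with a carbamoyloxy group on the saturated chain carbon (an 830-fold lower number from compound 1 to compound 4 (2.92 log units; beyond the scatter)). Nothing available accounts for the level readings of compounds 2, 3 and 4 or for the separate reading of compound 1.

The compounds shown leave open whether the amino group can itself be varied, for instance whether methylamino, dimethylamino or a plain methyl on the carbonyl carbon would stay level with compound 4. They also leave open how a hydroxy group or an amine in place of carbamoyloxy on the saturated chain carbon would read, and so which groups at this carbon share the low numbers of compounds 2, 3 and 4.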